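From iodo to heptyl on a sulfonamide core

The compounds below may be only part of what the source reports. "The series", "measured", "known", "first", "only" and "open" are said of these compounds alone.

Measured in a functional assay on HT-29 cells (Homo sapiens) for antiproliferative activity, read by sulforhodamine B assay, with a stated time of 48 h; on this read-out higher numbers stand for weaker inhibition and lower numbers for stronger inhibition:
Compound 1 `O=C1NCCN1c1ccc(S(=O)(=O)Nc2ccc(F)cc2)cc1`: 370 nM
Compound 2 `CCCCc1ccc(NS(=O)(=O)c2ccc(N3CCNC3=O)cc2)cc1`: 610 nM
Compound 3 `O=C1NCCN1c1ccc(S(=O)(=O)Nc2ccc(I)cc2)cc1`: 650 nM

The three values lie within the scatter of one another. Compound 3, at 650 nM, is not separated from the other two, as a 1.8-fold higher number from compound 1 to compound 3 (0.24 log units; within the scatter) and a 1.1-fold higher number from compound 2 to compound 3 (0.03 log units; within the scatter) show. The next compound is compound 4 `CCCCCCCc1ccc(NS(=O)(=O)c2ccc(N3CCNC3=O)cc2)cc1`, with heptyl in place of iodo on an aromatic carbon.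

Among the measured compounds shown here, three measured steps bear on this change. Butyl in place of fluoro gave a 1.6-fold higher number from compound 1 to compound 2 (0.22 log units; within the scatter), and iodo in place of fluoro gave a 1.8-fold higher number from compound 1 to compound 3 (0.24 log units; within the scatter). The only alkyl chain measured so far is the butyl of compound 2, and its exchange for iodo gave a 1.1-fold higher number from compound 2 to compound 3 (0.03 log units; within the scatter). For the measured compounds named here, none of these steps exceeds the scatter, but no measured compound carries a chain as long as heptyl, so the expectation is uncertain. The expected change is small, with a slight lean towards a higher number: a 1.2-fold higher number from compound 3 to compound 4 (0.09 log units; within the scatter). For compound 4 the estimated value is 800 nM, with an expected range from 250 nM to 2500 nM.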

Compound 4, half-maximal inhibitory concentration: > 1000 nM
Compound 4: no number, only a limit; the forecaster's own chance of this, stated with the estimate: 5%; at least 1.2-fold (0.09 log units) between middle value and limit.
By their numbers in this assay, from the lowest: compounds 1, 2 and 3 (each within the scatter of the next). At a limit, above all of these: compound 4.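

In this assay, compound 4 carries only a limit and not a number: the limit of > 1000 nM in this assay, at which 1 of the 4 values shown sits.

Among the compounds shown here, on this aromatic carbon, heptyl is the first group to stand apart from the fluoro of compound 1 beyond the scatter, with an at least 2.7-fold higher number from compound 1 to compound 4 (0.43 log units; beyond the scatter). The other steps, an at least 1.5-fold higher number from compound 3 to compound 4 (0.18 log units; that floor lies within the scatter) and an at least 1.6-fold higher number from compound 2 to compound 4 (0.21 log units; that floor lies within the scatter), have floors within the scatter, so heptyl is not yet separated from iodo or from butyl.

Where compound 4 truly lies beyond its limit stays open, as does whether chain length governs the read-out, since butyl and heptyl are the only chains shown. Also open, on these data alone, is what a shorter chain such as methyl, an amine or a carboxylic acid would give on this carbon.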